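A Methyl Added to the Anilino Group of Compound 3

The compounds below may be only part of what the source reports. "The series", "measured", "known", "first", "only" and "open" are said of these compounds alone.

Of the compounds shown here, three sharing one core have been tested in a functional assay on BGC-823 cells (Homo sapiens) for cytotoxicity, read by MTT assay; a higher number here means a weaker inhibitor, a lower number a stronger inhibitor. Compound 1 `COc1ccc(/C=C/C(=O)c2sc(Nc3ccc(Cl)cc3)nc2C)cc1` gives a value that is a limit of the assay, > 25000 nM. Compound 2 `COc1cccc(/C=C/C(=O)c2sc(Nc3ccccc3)nc2C)c1` gives 14300 nM. Compound 3 `Cc1nc(Nc2ccccc2)sc1C(=O)/C=C/c1ccc(Cl)cc1` also gives a limit of the assay, > 25000 nM. Among the measured compounds shown here, the only step between measured structures that differ in a single place is an at least 1.7-fold higher number from compound 2 to compound 3 (0.24 log units; that floor lies within the scatter). Compound 3 therefore stands at the limit of > 25000 nM in this assay, at which 2 of the 3 values shown sit, a place it shares with compound 1. Compound 4 `Cc1ccccc1Nc1nc(C)c(C(=O)/C=C/c2ccc(Cl)cc2)s1` is compound 3 with one change: methyl in place of hydrogen on an aromatic carbon. No measured step touches the anilino group, so nothing shown supports a movement in either direction, and the one measured step leading into compound 3 itself ended at a limit. The step that the limit leaves unreadable from compound 3 to compound 4 is therefore expected to be small. Compound 4 is estimated at 30000 nM, between 10000 nM and 100000 nM, with a limit again being the more likely outcome.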

Compound 4, half-maximal inhibitory concentration: > 25000 nM
Compound 4: no number, only a limit; the forecaster's own chance of this, stated with the estimate: 70%; the middle value does not contradict the limit.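

In this assay, compound 3 and compound 4 each give only a limit of the assay, not a number, so the step between them cannot be read. The compounds shown leave open whether swapping phenyl for 2-methylphenyl on the anilino nitrogen changes cytotoxicity at all.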